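Replacing one group on the thiocarbonyl carbon

The compounds below may be only part of what the source reports. "The series", "measured", "known", "first", "only" and "open" are said of these compounds alone.

Measured in a functional assay on HCT-116 cells (Homo sapiens) for antiproliferative activity, read by CCK-8 assay, with a stated time of 72 h; a lower number here means a stronger inhibitor, a higher number a weaker inhibitor:
Compound 1 `Nc1ccccc1NC(=O)c1ccc(CSC(=S)N2CCN(c3ccccc3)CC2)cc1`: 2330 nM
Compound 2 `Nc1ccccc1NC(=O)c1ccc(CSC(=S)N2CCc3ccccc32)cc1`: 2700 nM
Compound 3 `Nc1ccccc1NC(=O)c1ccc(CSC(=S)N2CCc3cc(Cl)ccc32)cc1`: 3210 nM

Compound 3, at 3210 nM, stands level with compound 1 and compound 2, within the scatter of both. The next compound, compound 4 `CC1CCCCN1C(=S)SCc1ccc(C(=O)Nc2ccccc2N)cc1`, keeps the shared core but carries 2-methylpiperidin-1-yl in place of 5-chloro-2,3-dihydro-1H-indol-1-yl on a thiocarbonyl carbon.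

Within the data shown here, only one measured step touches this group: a 1.2-fold higher number from compound 2 to compound 3 (0.08 log units; within the scatter), where chloro replaces hydrogen on an aromatic carbon. That step stays within the scatter. Compound 1 carries a quite different group at the same carbon, yet its 2330 nM also sits within the scatter of the other two. Among the measured compounds shown here, no measured compound holds the 2-methylpiperidin-1-yl group, so this evidence is indirect, and a step beyond the scatter is not expected in either direction in this assay.

The expected change is a 1.1-fold lower number from compound 3 to compound 4 (0.06 log units; within the scatter). For compound 4 the estimated value is 2800 nM, with an expected range of 1300 nM to 6000 nM.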

Compound 4, half-maximal inhibitory concentration: 1320 nM
For compound 4 the middle estimate is 2.1-fold (0.33 log units) above the measured one; the range from low to high includes it.
By their numbers in this assay, from the lowest: compounds 4, 1, 2 and 3 (each within the scatter of the next, the first and the last beyond it).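

In this assay, changing the group on the thiocarbonyl carbon gives a 2.4-fold lower number from compound 3 to compound 4 (0.39 log units; beyond the scatter) and a 2.0-fold lower number from compound 2 to compound 4 (0.31 log units; beyond the scatter). Among these compounds, these are the first steps at this position to go beyond the scatter, though both are modest, so this carbon tolerates 2-methylpiperidin-1-yl and the number can shift with the group placed there. No measured property of these compounds explains why the numbers move.

Going by these compounds, whether the gain depends on the methyl group of 2-methylpiperidin-1-yl or on the six-membered non-aromatic ring itself remains open. A plain piperidin-1-yl group or a morpholin-4-yl group at the same carbon would help separate these two possibilities.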